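The compounds below may be only part of what the source reports. "The series", "measured", "known", "first", "only" and "open" are said of these compounds alone.

Compound 1 `Cc1nnc(-c2nsc3ccccc23)o1` and compound 2 `CCc1nnc(-c2nsc3ccccc23)o1` share one core and differ only in the chain attached to it. In a functional assay on the whole organism for inhibition, with Rattus norvegicus as the target, with a stated time of 3.5 h, at a dose of 100 mg/kg by the oral route (a lower number here means less inhibition, a higher number more inhibition at the dose given (going by the name of the read-out)), compound 1 gives 21%, and compound 2 gives 18%. The step of a number 3 percentage points lower from compound 1 to compound 2 (within the scatter) shows that this change left the read-out essentially where it was. Compound 2 thus has the lower of the two numbers, though the gap to compound 1 lies within the scatter. Compound 3 `c1ccc(-c2nnc(-c3nsc4ccccc34)o2)cc1` carries phenyl in place of ethyl on an aromatic carbon. Going by the values given here, the only measured step that bears on this, a number 3 percentage points lower from compound 1 to compound 2 (within the scatter), concerns a far smaller change and was itself within the scatter, so it offers little guidance on a move to an aromatic group; with nothing else to go on, the step of a number 2 percentage points higher from compound 2 to compound 3 (within the scatter) is expected to remain within the scatter. Compound 3 is therefore estimated to give 20% in this assay, with a range from 5% to 40%.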

Compound 3, a percentage reported as inhibition, in the whole organism at one dose (the size of the read-out at that dose, not a potency): 32%
Compound 3: middle estimate off by 12 percentage points, on the low side; measured number inside the range.
By their numbers in this assay, from the lowest: compounds 2 and 1 (each within the scatter of the next); then compound 3.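

In this assay, the read-out proves able to move at this aromatic carbon of the five-membered ring: phenyl in place of ethyl gives a number 14 percentage points higher from compound 2 to compound 3 (beyond the scatter), and phenyl in place of methyl gives a number 11 percentage points higher from compound 1 to compound 3 (beyond the scatter). Both steps are modest, yet each lies beyond the scatter, whereas the step between the two small chains did not. Nothing measured here accounts for the separation of the phenyl compound from the two chain compounds.

The compounds shown leave open whether the aromatic ring itself matters or only the greater number of carbons; a longer chain such as butyl or a saturated cyclohexyl ring would separate the two. They also leave open how a methoxy group or an amine on the phenyl ring would shift the number.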